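The source may hold more compounds than are shown below. What is called first, only, known or untested is meant among the compounds shown, and "the series" means these compounds.

In a functional assay on HeLa cells (Homo sapiens) for antiproliferative activity, read by CCK-8 assay, with a stated time of 72 h, tested at 2 uM (a higher number here means a stronger effect of the compound at the concentration tested, a lower number a weaker effect), compound 1 `Nc1ccccc1NC(=O)c1ccc(CSC(=S)N2CCN(c3ccccc3)CC2)cc1` gives 62.2%, compound 3 `CC1CCCCN1C(=S)SCc1ccc(C(=O)Nc2ccccc2N)cc1` gives 45.5%, and compound 2 `COc1ccc(N2CCN(C(=S)SCc3ccc(C(=O)Nc4ccccc4N)cc3)CC2)cc1` gives 39.4%, the lowest number of the three, separated from compound 3 by less than the scatter and from compound 1 by more. Among the compounds with values here, the only one-place step measured so far is a number 22.8 percentage points lower from compound 1 to compound 2 (beyond the scatter). Compound 4 `Cc1ccc(N2CCN(C(=S)SCc3ccc(C(=O)Nc4ccccc4N)cc3)CC2)cc1` differs from compound 2 by methyl in place of methoxy on an aromatic carbon. That earlier step bears on the change here only in part: the methoxy leaves, yet a methyl enters rather than a hydrogen. A rise partway back toward the number of compound 1 is therefore expected. The change expected is a number 10.6 percentage points higher from compound 2 to compound 4 (beyond the scatter), a smaller move than the one measured earlier. Compound 4 is expected to give 50%, in a range from 36% to 64%.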

Compound 4, a percentage reported as inhibition, at one concentration (the size of the read-out at that concentration, not a potency): 25.3%
Estimate against measurement, compound 4: 24.7 percentage points above; the whole stated range lies above it.
By their numbers in this assay, from the lowest: compound 4; then compounds 2 and 3 (each within the scatter of the next); then compound 1.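

In this assay, the change from 4-methoxyphenyl to 4-methylphenyl gives a number 14.1 percentage points lower from compound 2 to compound 4 (beyond the scatter), so losing the methoxy does not move the number back toward that of compound 1. Methyl in place of hydrogen on the same aromatic carbon, para to a large group, gives a number 36.9 percentage points lower from compound 1 to compound 4 (beyond the scatter). Among these three compounds, hydrogen therefore stands above both substituents, and the methyl and methoxy steps from compound 1 both lie beyond the scatter.

On these data alone, whether a fluorine, an amine or a carboxylic acid on this carbon would follow the same pattern remains open. No available evidence accounts for the order of these three compounds.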